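Swapping the ring-bearing group on compound 2

This account rests on a few compounds, and the source may have more. Where it says the series, first, only, none or still open, it means among the compounds named here.

Compound 1 `CC(C)c1noc(N2CCC(Oc3cc(N4CCc5cc(N6CCCNS6(=O)=O)ccc54)ncn3)CC2)n1`: 3.2
Compound 2 `CC(C)c1noc(N2CCC(Oc3cc(N4CCc5cc(N6CCCS6(=O)=O)ccc54)ncn3)CC2)n1`: 3.2

In a physicochemical assay for lipophilicity, measured as octanol-water partition, at pH 7.4 (on this read-out higher numbers stand for higher lipophilicity and lower numbers for lower lipophilicity), compound 2 stands at 3.2, level with compound 1 at the digits shown. Compound 3 `CC(C)c1noc(N2CCC(Oc3cc(N4CCc5cc([S+]([O-])CCO)ccc54)ncn3)CC2)n1` has not been measured. It differs from compound 2 as follows: a group of 5 heavy atoms (2 carbon, 2 oxygen, 1 sulfur; no ring) in place of a group of 7 heavy atoms (3 carbon, 1 nitrogen, 2 oxygen, 1 sulfur; one five-membered non-aromatic ring with 2 hetero atoms), on an aromatic carbon. For the measured compounds named here, the only measured step, no change at the digits printed from compound 1 to compound 2 (within the scatter), exchanged one ring for another, so it is a weak guide to a group with no ring. Going by the values given here, the data hold no direct precedent, but a modest fall is expected, a number 0.60 log units lower from compound 2 to compound 3 (beyond the scatter). For compound 3 the estimated value is 2.6, with an expected range of 2.1 to 3.1.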

Compound 3, distribution coefficient: 2.7
The estimate for compound 3 lay 0.10 log units below the measured number; the range from low to high includes it.
By their numbers in this assay, from the lowest: compound 3; then compounds 1 and 2 (each within the scatter of the next).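

In this assay this aromatic carbon proved responsive to the group it carries: the group of 5 heavy atoms with no ring gave a number 0.50 log units lower from compound 2 to compound 3 (beyond the scatter) and a number 0.50 log units lower from compound 1 to compound 3 (beyond the scatter), whereas exchanging one ring for the other had moved nothing beyond the scatter. Neither ring-bearing compound differs from the other in this respect, as both steps have the same size. Nothing available explains the fall.

On these data alone, whether it follows the loss of the ring or the arrival of the hydrogen-bond donor remains open, as both change together here. As far as these compounds go, how an amine, a carboxylic acid or a longer chain on this carbon would compare also remains open.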